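The compounds below may be only part of what the source reports. "The series", "measured", "known", "first", "only" and "open" are said of these compounds alone.

Measured compounds in a functional assay on PANC-1 cells (Homo sapiens) for inhibition, read by MTT assay, with a stated time of 24 h, tested at 10 uM; on this read-out lower numbers stand for less inhibition and higher numbers for more inhibition at the one concentration tested (going by the name of the read-out):
compound 1 `CC(C)=CCC1Cc2c(OCCCOc3ccc([N+](=O)[O-])cc3)cc(=O)n(CCCO)c2CC1(C)C` gives 47.5%
compound 2 `CC(C)=CCC/C(C)=C/CC1Cc2c(OCCCNS(=O)(=O)c3ccc(Cl)cc3)cc(=O)n(CCCO)c2CC1(C)C` gives 14.5%
compound 3 `COc1ccc(C(=O)NCCCOc2cc(=O)n(CCCO)c3c2CC(C/C=C(\C)CCC=C(C)C)C(C)(C)C3)cc1` gives 45.7%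

Compound 3 stands second highest of the three numbers; compound 1 lies within the scatter of it, while compound 2 lies far lower. Compound 4 `CC(C)=CCC/C(C)=C/CC1Cc2c(OCCCOc3ccc([N+](=O)[O-])cc3)cc(=O)n(CCCO)c2CC1(C)C` differs from compound 3 by 4-nitrophenoxy in place of ((4-methoxyphenyl)carbonyl)amino on a saturated chain carbon, three bonds along the chain from an oxygen on an aromatic ring.

Within the data shown here, the only measured step at this position, a number 31.2 percentage points higher from compound 2 to compound 3 (beyond the scatter), was large but concerned other groups. Compound 1 already carries the entering 4-nitrophenoxy group and its number in this assay sits within the scatter of compound 3, so no step beyond the scatter is expected, a number 0.3 percentage points higher from compound 3 to compound 4 (within the scatter). Compound 4 is accordingly estimated at 46%, with a range from 30% to 60%.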

Compound 4, a percentage reported as inhibition, at one concentration (the size of the read-out at that concentration, not a potency): 65.1%
Compound 4: the middle estimate sits 19.1 percentage points below what was measured; measured number above the stated range.
By their numbers in this assay, from the lowest: compound 2; then compounds 3 and 1 (each within the scatter of the next); then compound 4.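

In this assay, the group at the chain end matters: 4-nitrophenoxy brings a number 19.4 percentage points higher from compound 3 to compound 4 (beyond the scatter) over ((4-methoxyphenyl)carbonyl)amino and a number 50.6 percentage points higher from compound 2 to compound 4 (beyond the scatter) over ((4-chlorophenyl)sulfonyl)amino. With 4-nitrophenoxy held fixed, 3-methylbut-2-en-1-yl in place of hydrogen also counts, giving a number 17.6 percentage points higher from compound 1 to compound 4 (beyond the scatter) on a saturated chain carbon bound to a double-bonded chain carbon. No evidence at hand bears on either change.

Still open, as far as these compounds go, is whether plain phenoxy or 4-aminophenoxy at the chain end would hold this level, and whether a still longer terpene chain would add further.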